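A single fluorine added to the central ring

The source may report more compounds than this note shows. Statements on the series, on what has been measured and on what is new or still open speak of the compounds shown alone.

Measured so far:
compound 1 `O=C(Nc1ccc(Oc2ccnc3[nH]ccc23)cc1)c1cn(-c2ccc(F)cc2)c2ccccc2c1=O`, 720 nM in a functional assay on MCF7 cells (Homo sapiens) for inhibition, read by MTT assay, with a stated time of 72 h; a higher number here means a weaker inhibitor, a lower number a stronger inhibitor
compound 2 `O=C(Nc1ccc(Oc2ccnc3[nH]ccc23)cc1)c1cn(-c2ccc(Br)cc2)c2ccccc2c1=O`, 610 nM
compound 3 `O=C(Nc1ccc(Oc2ccnc3[nH]ccc23)cc1)c1cn(-c2ccc(C(F)(F)F)cc2Cl)c2ccccc2c1=O`, 3570 nM

Compound 1 stands second highest of the three numbers, with compound 2 within the scatter (a 1.2-fold lower number from compound 1 to compound 2 (0.07 log units; within the scatter)) and compound 3 clearly higher (a 5.0-fold higher number from compound 1 to compound 3 (0.70 log units; beyond the scatter)). Compound 4 `O=C(Nc1ccc(Oc2ccnc3[nH]ccc23)c(F)c1)c1cn(-c2ccc(F)cc2)c2ccccc2c1=O` differs from compound 1 only by fluoro in place of hydrogen on an aromatic carbon, on the central six-membered ring of carbon only. Every measured step changes the group on the aromatic nitrogen instead, so none of them bears on this place; the nearest analogy is the small step of a 1.2-fold lower number from compound 1 to compound 2 (0.07 log units; within the scatter) for a modest halogen swap. For compound 4 the step of a 1.0-fold lower number from compound 1 to compound 4 (0.01 log units; within the scatter) is expected, within the scatter. Compound 4 is therefore estimated at 700 nM, between 300 nM and 1700 nM.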

Compound 4, half-maximal inhibitory concentration: 520 nM
Compound 4: the middle estimate sits 1.3-fold (0.13 log units) above what was measured; measured number inside the range.
By their numbers in this assay, from the lowest: compounds 4, 2 and 1 (each within the scatter of the next); then compound 3.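

In this assay a change on the ring of carbon only, rather than on the aromatic nitrogen, gives a 1.4-fold lower number from compound 1 to compound 4 (0.14 log units; within the scatter) and so opens this position to view. Fluoro in place of hydrogen here, ortho to a large group and meta to a large group, leaves the number indistinguishable from that of compound 1. Nothing available explains this result.

Going by these compounds, whether methoxy or an amine would be accepted at this place stays open. So does whether fluoro here would behave the same alongside the 2-chloro-4-(trifluoromethyl)phenyl group of compound 3.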